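Trading the amine chain for a carbocycle

The source may hold more compounds than are shown below. What is called first, only, known or untested is meant among the compounds shown, and "the series" means these compounds.

Going by the values given here, compound 1 `CC1CCN(CCCSc2nc(C(F)(F)F)ccc2CNC(=O)C(C)c2ccc(NS(C)(=O)=O)c(F)c2)CC1` stands lowest of the two numbers measured so far: in an assay on CHO-K1 cells for antagonist activity at transient receptor potential cation channel subfamily V member 1 (Homo sapiens), read by FLIPR (a lower number here means a stronger inhibitor, a higher number a weaker inhibitor), compound 1 gives 2.9 nM, whereas compound 2 `CC(C(=O)NCc1ccc(C(F)(F)F)nc1SCCC(=O)N1CCCC1)c1ccc(NS(C)(=O)=O)c(F)c1` gives 85 nM. Among the compounds with values here, the single measured step, a 29-fold higher number from compound 1 to compound 2 (1.47 log units; beyond the scatter), removes the 4-methylpiperidin-1-yl group and is large. Compound 3 `CC1CCC(Sc2nc(C(F)(F)F)ccc2CNC(=O)C(C)c2ccc(NS(C)(=O)=O)c(F)c2)CC1` carries 4-methylcyclohexyl in place of 3-(4-methylpiperidin-1-yl)propyl on a sulfur, again removing that group together with the one hydrogen-bond acceptor it held. The expected step is therefore a large loss, a 34-fold higher number from compound 1 to compound 3 (1.54 log units; beyond the scatter), by analogy with a 29-fold higher number from compound 1 to compound 2 (1.47 log units; beyond the scatter). Compound 3 is estimated at 100 nM, expected between 20 nM and 600 nM.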

Compound 3, inhibition constant: 0.5 nM
Compound 3: middle estimate off by 200-fold (2.30 log units), on the high side; the measured number lies below the stated range.
By their numbers in this assay, from the lowest: compound 3; then compound 1; then compound 2.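

The sulfur substituent need not carry a ring nitrogen or a propyl chain for a low number: 4-methylcyclohexyl in place of 3-(4-methylpiperidin-1-yl)propyl gives a 5.8-fold lower number from compound 1 to compound 3 (0.76 log units; beyond the scatter). Against the 2-((pyrrolidin-1-yl)carbonyl)ethyl chain, the same group gives a 170-fold lower number from compound 2 to compound 3 (2.23 log units; beyond the scatter). Nothing measured here accounts for either step.

The ring nitrogen and the propyl chain leave together, so their contributions cannot be separated. On these data alone, whether an unsubstituted cyclohexyl, an open alkyl chain or a piperidine ring bound directly to the sulfur would keep the number this low remains open.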